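The compounds below may be only part of what the source reports. "The series", "measured", "known", "first", "only" and "open" are said of these compounds alone.

In a functional assay on HepG2 cells (Homo sapiens) for inhibition, read by MTT assay, with a stated time of 48 h (on this read-out higher numbers stand for weaker inhibition and lower numbers for stronger inhibition), the measured compounds read as follows:

- Compound 1 `COc1ccc(-n2c(S)nnc2-c2cc(OC)c(OC)c(OC)c2)cc1`: 57500 nM.
- Compound 2 `CCSc1nnc(-c2cc(OC)c(OC)c(OC)c2)n1-c1ccc(OC)cc1`: > 60000 nM, a limit of the assay.
- Compound 3 `COc1cc(-c2nnc(S)n2-c2ccc(N(C)C)cc2)cc(OC)c1OC`: > 60000 nM, a limit of the assay.

Compound 3 therefore has no exact number, only the limit > 60000 nM. Compound 2 stands at the same limit, as the limit of > 60000 nM in this assay, at which 2 of the 3 values shown sit, shows.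

Compound 4 `CCSc1nnc(-c2cc(OC)c(OC)c(OC)c2)n1-c1ccc(N(C)C)cc1` carries ethyl in place of hydrogen on a sulfur, a difference counted as ethyl in place of hydrogen on a sulfur.

The same exchange has been measured once, as an at least 1.0-fold higher number from compound 1 to compound 2 (0.01 log units; that floor lies within the scatter). The other measured step, with dimethylamino in place of methoxy on an aromatic carbon, links the two starting compounds as an at least 1.0-fold higher number from compound 1 to compound 3 (0.01 log units; that floor lies within the scatter). Both steps end at a limit, so neither gives a true size.

Going by the values given here, with compound 2 as the only precedent for this exchange, at > 60000 nM, no step beyond the scatter can be predicted, and the assay will probably report a limit again. The expected step is a step that the limit leaves unreadable from compound 3 to compound 4.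

For compound 4, the estimated value is 75000 nM, with an expected range from 40000 nM to 150000 nM.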

Compound 4, half-maximal inhibitory concentration: > 60000 nM
Compound 4 gave a limit, no number; the forecaster's own chance of this, stated with the estimate: 85%; the middle value is on the limit's open side.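

Going by these compounds alone, compound 4 reads > 60000 nM as a limit of the assay, and no step to it from compound 2 or compound 3 can be read, since those compounds also stop at a limit: the limit of > 60000 nM in this assay, at which 3 of the 4 values shown sit.

The compounds shown leave open how compound 2, compound 3 and compound 4 rank against one another.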